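This account rests on a few compounds, and the source may have more. Where it says the series, first, only, none or still open, it means among the compounds named here.

Series read in an ADME assay on HEK-293T cells (Homo sapiens) for cytotoxicity, read by MTT assay, with a stated time of 48 h; a lower number here means that less compound is tolerated, a higher number that more compound is tolerated; every value shown is a limit of the assay, not a number.

Compound 1 `Cn1cc(C2CC(c3ccccc3)=NN2C(=O)c2cccnc2)c2cc(Br)ccc21`: > 300000 nM
Compound 2 `COc1ccc2c(c1)c(C1CC(c3ccccc3)=NN1C(=O)c1cccnc1)cn2C`: > 300000 nM
Compound 3 `COc1ccc2c(c1)c(C1CC(c3ccc(Br)cc3)=NN1C(=O)c1ccc(OC)nc1)cn2C`: > 300000 nM

Compound 2 arises from compound 1 by methoxy in place of bromo on an aromatic carbon. Because both sit at the limit of > 300000 nM in this assay, at which 3 of the 3 values shown sit, the step that the two limits leave unreadable from compound 1 to compound 2 cannot be sized. The difference between the core of compound 1 and the core of compound 3 is not broken down here.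

Compound 4 `COc1ccc(C2=NN(C(=O)c3ccc(OC)nc3)C(c3cn(C)c4ccc(OC)cc34)C2)cc1` is not yet measured. It arises from compound 3 by methoxy in place of bromo on an aromatic carbon. This is the same kind of change as that from compound 1 to compound 2, not the same: there the group sits on a ring that is part of a fused or bridged system of two rings, meta to a fused ring and para to a fused ring; here it sits on a six-membered aromatic ring of carbon only, para to a large group.

For compound 4 in this assay, the step that the limit leaves unreadable from compound 3 to compound 4 is expected to be no larger than the earlier, unreadable one, resting on compound 3 giving > 300000 nM. Compound 4 is therefore estimated at 400000 nM, between 150000 nM and 1000000 nM, most likely reported as a limit again.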

Compound 4, half-maximal cytotoxic concentration: > 300000 nM
Compound 4 was reported as a limit (the forecaster's own chance of this, stated with the estimate: 85%); the middle value lies beyond the limit too.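

No new step can be read from compound 3 to compound 4, 4-bromophenyl to 4-methoxyphenyl, because both values are limits in this assay: the limit of > 300000 nM in this assay, at which 4 of the 4 values shown sit.

The compounds shown leave open where any half-maximal cytotoxic concentration in the series lies, and whether exchanging bromo for methoxy changes it at either place.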